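From pyridin-4-yl to 1H-indol-7-yl

The source may report more compounds than this note shows. Statements on the series, on what has been measured and on what is new or still open speak of the compounds shown alone.

In a functional assay on SK-OV-3 cells (Homo sapiens) for cytotoxicity, read by spectrophotometry, with a stated time of 72 h (a lower number here means a stronger inhibitor, a higher number a weaker inhibitor), compound 1 `COc1ccc(-c2cccc(=O)n2-c2cc(OC)c(OC)c(OC)c2)cc1OCc1ccccc1` gives 2310 nM, compound 2 `COc1cc(-n2c(-c3cccc(F)c3)cccc2=O)cc(OC)c1OC` gives 472 nM, and compound 3 `COc1cc(-n2c(-c3ccncc3)cccc2=O)cc(OC)c1OC` gives 1790 nM. Compound 3 thus lies within the scatter of compound 1, and its number is clearly higher than that of compound 2.

Next in line is compound 4 `COc1cc(-n2c(-c3cccc4cc[nH]c34)cccc2=O)cc(OC)c1OC`, reached from compound 3 by one change: 1H-indol-7-yl in place of pyridin-4-yl on an aromatic carbon. Among the measured compounds shown here, only one measured step bears on it, a 3.8-fold higher number from compound 2 to compound 3 (0.58 log units; beyond the scatter), a modest step beyond the scatter, made at the same carbon. There, pyridin-4-yl came in and the number rose. For the measured compounds named here, no compound with 1H-indol-7-yl has been measured, so the evidence is thin. Replacing pyridin-4-yl with a group that holds a six-membered carbon ring is still expected to lower the number in this assay, by a step of similar modest size. The estimated step is a 3.6-fold lower number from compound 3 to compound 4 (0.55 log units; beyond the scatter). The expected value for compound 4 is 500 nM, within a range of 100 nM to 2000 nM.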

Compound 4, half-maximal inhibitory concentration: 138 nM
For compound 4 the middle estimate is 3.6-fold (0.56 log units) above the measured one, and the stated range covers the measured number.
By their numbers in this assay, from the lowest: compound 4; then compound 2; then compounds 3 and 1 (each within the scatter of the next).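

At this carbon, next to the ring nitrogen, enlarging the aromatic group from a single ring to 1H-indol-7-yl gives a large change in this assay, a 13-fold lower number from compound 3 to compound 4 (1.11 log units; beyond the scatter), showing that this position accepts a group with two aromatic rings. The gain is not confined to the comparison with pyridin-4-yl: 1H-indol-7-yl also improves on 3-fluorophenyl, with a 3.4-fold lower number from compound 2 to compound 4 (0.53 log units; beyond the scatter), so the group at this carbon can still move the number beyond that reached with a substituted phenyl. Nothing measured here accounts for the size of either step.

The compounds shown do not separate the hydrogen-bond donor of 1H-indol-7-yl from its added ring. On these data alone, how naphthalen-1-yl, which has two six-membered carbon rings and no ring nitrogen, or 1H-indol-5-yl, which has the same atoms attached at another ring carbon, stands at this carbon remains open.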